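The compounds below may be only part of what the source reports. "The series", "measured", "known", "first", "only" and "open" are said of these compounds alone.

The study turns on a shared core bearing a phenyl group and a basic amine tethered through an alkoxy chain. Compound 1 `CN1CCN(CCCCOc2c(O)cc3oc(-c4ccccc4)cc(=O)c3c2O)CC1` carries a hydroxy group on the aromatic ring and a methylpiperazine on the chain; in a functional assay on HepG2 cells (Homo sapiens) for antiproliferative activity, read by MTT assay, with a stated time of 48 h (on this read-out lower numbers stand for stronger inhibition and higher numbers for weaker inhibition), compound 1 gives 93700 nM. Compound 2 `O=c1cc(-c2ccccc2)oc2cc(O)c(OCCCN3CCCC3)c(O)c12` carries a pyrrolidine on a shorter chain, and in this assay compound 2 reaches only a limit of the assay, > 100000 nM. Compound 3 `O=c1cc(-c2ccccc2)oc2cc(OCc3ccccc3)c(OCCCCN3CCCCC3)c(O)c12` replaces the hydroxy group with benzyloxy and carries a piperidine; in this assay compound 3 gives 2400 nM, the lower of the two numbers recorded. Among the measured compounds shown here, the only single-point step measured, an at least 1.0-fold higher number from compound 1 to compound 2 (0.02 log units; that floor lies within the scatter), concerns the amine and not the benzyl group, so no measured step bears directly on the change toward compound 4. Compound 4 `O=c1cc(-c2ccccc2)oc2cc(O)c(OCCCCN3CCCCC3)c(O)c12` differs from compound 3 by hydrogen in place of benzyl on an oxygen on an aromatic ring. Compound 1, which carries hydroxy on that oxygen on an aromatic ring, gives 93700 nM, and that points toward a weaker result. Compound 4 is therefore expected to show a step of a 13-fold higher number from compound 3 to compound 4 (1.10 log units; beyond the scatter) in this assay. The estimate for compound 4 is 30000 nM, expected to fall between 6000 nM and 100000 nM.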

Compound 4, half-maximal inhibitory concentration: > 100000 nM
Compound 4: a limit, no number; the forecaster's own chance of this, stated with the estimate: 25%; middle value at least 3.3-fold (0.52 log units) away from the limit.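

Among the compounds shown here, with the butyl-linked piperidine held constant, replacing benzyl by hydrogen on the oxygen on an aromatic ring gives an at least 41-fold higher number from compound 3 to compound 4 (1.61 log units; beyond the scatter) in this assay, the first readable step at this position, and it shows that the measured activity of compound 3 is lost once benzyloxy becomes hydroxy. The amine offers no comparable reading with hydroxy in place: the change from 4-methylpiperazin-1-yl to piperidin-1-yl gives an at least 1.0-fold higher number from compound 1 to compound 4 (0.02 log units; that floor lies within the scatter), and since compound 4 stands at a limit of the assay and not at a number, this is only a floor. Compound 2 also stands at that limit, so the step between compound 2 and compound 4 cannot be read, and the hydroxy compounds separate poorly from one another: the limit of > 100000 nM in this assay, at which 2 of the 4 values shown sit.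

The compounds shown leave open whether benzyl itself is needed on this oxygen, or whether a methyl or a 4-fluorobenzyl group there would serve as well. They also leave open how far the amine and the chain matter once benzyloxy is present, for instance with a pyrrolidine or a 4-methylpiperazine on the butyl chain, or with a shorter chain carrying the piperidine.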